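Moving a methyl group on the aromatic ring

A few compounds are considered here, and "the series" means these few. Any claim that something is new, unique, unknown or untested is made for them only; others in the source may bear on it.

In a functional assay on KB cells (Homo sapiens) for cytotoxicity (a lower number here means that less compound is needed, a higher number that more compound is needed for the effect), compound 1 `COC1=C(C)C(=O)/C(=C(O)/C=C/c2ccc(OC)cc2)C(=O)C1(C)C` gives 3.6 ug/mL, compound 2 `COC1=C(C)C(=O)/C(=C(O)/C=C/c2cccc(OC)c2)C(=O)C1(C)C` gives 3.3 ug/mL and compound 3 `COC1=C(C)C(=O)/C(=C(O)/C=C/c2ccc(C)cc2)C(=O)C1(C)C` gives 3.9 ug/mL, so compound 3 stands level with the other two within the scatter. Compound 4 `COC1=C(C)C(=O)/C(=C(O)/C=C/c2ccccc2C)C(=O)C1(C)C` carries 2-methylphenyl in place of the 4-methylphenyl of compound 3 (2-methylphenyl in place of 4-methylphenyl on a double-bonded chain carbon bound to a double-bonded chain carbon). Among the measured compounds shown here, the nearest precedent is 3-methoxyphenyl in place of 4-methoxyphenyl, which gave a 1.1-fold lower number from compound 1 to compound 2 (0.04 log units; within the scatter). Methyl in place of methoxy gave a 1.1-fold higher number from compound 1 to compound 3 (0.03 log units; within the scatter). For the measured compounds named here, no measured compound carries 2-methylphenyl, so this rests on limited evidence, but no change beyond the scatter is expected in this assay. The expected step is a 1.1-fold lower number from compound 3 to compound 4 (0.02 log units; within the scatter). Compound 4 is estimated at 3.7 ug/mL, with an expected range of 2.2 ug/mL to 6.5 ug/mL.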

Compound 4, concentration for half-maximal effect: 4.1 ug/mL
The estimate for compound 4 lay 1.1-fold (0.04 log units) below the measured number; low and high end bracket the measured number.
By their numbers in this assay, from the lowest: compounds 2, 1, 3 and 4 (each within the scatter of the next).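

Among the compounds shown here, changing 4-methylphenyl to 2-methylphenyl, a ring no earlier compound carried, gives a 1.1-fold higher number from compound 3 to compound 4 (0.02 log units; within the scatter) in this assay, so the methyl group can take either of these two places without a change beyond the scatter. Comparison with the methoxy compounds gives a 1.1-fold higher number from compound 1 to compound 4 (0.06 log units; within the scatter) and a 1.2-fold higher number from compound 2 to compound 4 (0.09 log units; within the scatter) and likewise shows no step beyond the scatter at this position. No evidence is available to explain these results.

Still open, going by these compounds, is whether an amine or a carboxylic acid on this ring would give a step beyond the scatter. A longer chain in place of the methyl group also remains untested among the compounds shown.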